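A side chain on a compound at the assay limit

This account rests on a few compounds, and the source may have more. Where it says the series, first, only, none or still open, it means among the compounds named here.

Measured in a functional assay (strain AB) with Danio rerio as the target, read by microscopy, with a stated time of 1 h; on this read-out higher numbers stand for an effect only at larger amounts of compound and lower numbers for an effect already at smaller amounts:
- compound 1 `NC(=O)c1c(NC(=O)Nc2ccc(Cl)cc2)sc2c1CCCC2`: > 25000 nM (a limit)
- compound 2 `CCN1CCc2c(sc(NC(=O)Nc3ccc(C(F)(F)F)cc3)c2C(N)=O)C1`: 2910 nM
- compound 3 `CCN1CCc2c(sc(NC(=O)NCc3cccc(Cl)c3)c2C(N)=O)C1`: > 25000 nM (a limit)

Compound 1 stands at > 25000 nM, which is a limit of the assay and not a number. Compound 3 also gives a limit, > 25000 nM. Only compound 2 has a true number, 2910 nM.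

Compound 4 `CCC(C)(C)C1CCc2c(sc(NC(=O)Nc3ccc(Cl)cc3)c2C(N)=O)C1` has not yet been measured. It keeps the core of compound 1 and adds one side chain: 1,1-dimethylpropyl in place of hydrogen on a saturated ring carbon. Within the data shown here, no pair of measured compounds shows a step of this kind, so the expectation is tentative. Compound 2 at 2910 nM shows that a number can be reached in this assay, and a shift towards lower numbers is expected. For compound 4 the limit may well persist. The expected change is an at least 6.2-fold lower number from compound 1 to compound 4 (0.79 log units; beyond the scatter). For compound 4 the estimate is 4000 nM, with an expected range from 400 nM to 25000 nM.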

Compound 4, half-maximal effective concentration: > 25000 nM
Compound 4 ended at the assay's limit; the forecaster's own chance of this, stated with the estimate: 35%; middle value at least 6.2-fold (0.79 log units) from the limit.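

Compound 4 gives > 25000 nM, which is a limit and not a number, and compound 1 also stands at a limit, so no step can be read between compound 1 and compound 4. The compounds shown leave open whether the 1,1-dimethylpropyl side chain changes the effect in either direction.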